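The source may hold more compounds than are shown below. What is called first, only, known or untested is meant among the compounds shown, and "the series" means these compounds.

Compound 1 `O=C(Nc1ccc(Oc2ccnc3[nH]ccc23)cc1)c1nn(-c2ccc(Cl)cc2)ccc1=O` was tested in a functional assay on HepG2 cells (Homo sapiens) for cytotoxicity, read by MTT assay, with a stated time of 72 h (a higher number here means a weaker inhibitor, a lower number a stronger inhibitor), where compound 1 gives 19500 nM. Compound 2 `O=C(Nc1ccc(Oc2ccnc3[nH]ccc23)cc1)c1nn(-c2ccc(Br)cc2)ccc1=O` differs from compound 1 only in the halogen, the difference being chloro in place of bromo on an aromatic carbon read in the reverse direction, and in this assay compound 2 gives 4280 nM, a step of a 4.6-fold lower number from compound 1 to compound 2 (0.66 log units; beyond the scatter). Compound 3 `O=C(Nc1ccc(Oc2ccnc3[nH]ccc23)cc1)c1nn(-c2ccc(Br)cc2F)ccc1=O` adds a fluoro to compound 2, the difference (fluoro in place of hydrogen on an aromatic carbon), and in this assay compound 3 gives 46400 nM. That addition made a step of an 11-fold higher number from compound 2 to compound 3 (1.04 log units; beyond the scatter), and measured against compound 1 the step is a 2.4-fold higher number from compound 1 to compound 3 (0.38 log units; beyond the scatter).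

Compound 4 `O=C(Nc1ccc(Oc2ccnc3[nH]ccc23)c(F)c1)c1nn(-c2ccc(Cl)cc2)ccc1=O` has not yet been measured. It differs from compound 1 by fluoro in place of hydrogen on an aromatic carbon. Within the data shown here, this is the same kind of change as the one from compound 2 to compound 3, though not the same change: in compound 3 the fluoro sits ortho to a large group and meta to a bromo group, whereas in compound 4 it sits ortho to a large group and meta to a large group, on another ring of the shared core. Among the measured compounds shown here, the only precedent for adding a fluoro is the step of an 11-fold higher number from compound 2 to compound 3 (1.04 log units; beyond the scatter), which was large. Because of an 11-fold higher number from compound 2 to compound 3 (1.04 log units; beyond the scatter) the author expects compound 4 to give a higher number than compound 1. The setting is not the same and the precedent is a single example, so a smaller step is expected, and compound 4 is expected to show a step of a 2.3-fold higher number from compound 1 to compound 4 (0.36 log units; beyond the scatter). Compound 4 is estimated at 45000 nM, with a likely range from 15000 nM to 130000 nM.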

Compound 4, half-maximal inhibitory concentration: > 60000 nM
Compound 4: a limit, no number; the forecaster's own chance of this, stated with the estimate: 20%; at least 1.3-fold (0.12 log units) between middle value and limit.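

In this assay compound 4 gives > 60000 nM, which is a limit of the assay and not a number. Even so, the step can be read as an at least 3.0-fold higher number from compound 1 to compound 4 (0.48 log units; beyond the scatter), so adding a fluoro gave a higher number on both cores shown, though the fluoro stands on a different ring in each. This shows only that the direction of the change held in these two pairs, not that it would hold across the series, and the size of the step on the core of compound 1 cannot be set against the earlier one: the same change on two cores in this assay, an 11-fold higher number (1.04 log units; beyond the scatter) from compound 2 to compound 3 and an at least 3.0-fold higher number (0.48 log units; beyond the scatter) from compound 1 to compound 4; the limit leaves it open whether they differ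

Going by these compounds, how far the true value of compound 4 lies past the limit stays open, and the same limit would also apply to any further compound in this assay that reached it: the limit of > 60000 nM in this assay, at which 1 of the 4 values shown sits. Open too is whether a methoxy or an amine on that same aromatic carbon of the shared core would shift the number as the fluoro does, and how a fluoro on the 4-chlorophenyl ring of compound 1 would compare with the fluoro on the ring of compound 3.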